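The source may report more compounds than this note shows. Statements on the series, on what has been measured and on what is new or still open speak of the compounds shown alone.

Measured in a functional assay on cells (Platelet, Homo sapiens) for inhibition; a higher number here means a weaker inhibitor, a lower number a stronger inhibitor:
- Compound 1 `CC(C)OC(=O)c1ccc(-c2nn(Cc3ccccc3)c3ccccc23)cc1`: > 10000 nM
- Compound 2 `NC(=O)c1ccc(-c2nn(Cc3ccccc3)c3ccccc23)cc1`: > 10000 nM
- Compound 3 `CNC(=O)c1ccc(-c2nn(Cc3ccccc3)c3ccccc23)cc1`: > 10000 nM

All three compounds stop at the same ceiling, (the limit of > 10000 nM in this assay, at which 3 of the 3 values shown sit). In this assay compound 3 gives > 10000 nM, which is a limit of the assay and not a number. Its true position is therefore unknown.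

Compound 4 `CC(C)NC(=O)c1ccc(-c2nn(Cc3ccccc3)c3ccccc23)cc1` changes only the group on the amide-type nitrogen of compound 3: isopropyl in place of methyl on an amide-type nitrogen. In words, this puts isopropyl in place of methyl on an amide-type nitrogen.

The closest measured change, methyl in place of hydrogen on an amide-type nitrogen, is a step that the two limits leave unreadable from compound 2 to compound 3. Changes on the carbonyl carbon give a step that the two limits leave unreadable from compound 1 to compound 2 and a step that the two limits leave unreadable from compound 1 to compound 3. None of these steps has a readable size, so they offer no direction for the new change. The expected step is a step that the limit leaves unreadable from compound 3 to compound 4, with no direction supported by the data. Compound 4 is expected to stay weak, with an estimated value of 12000 nM and an estimated range from 4000 nM to 40000 nM.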

Compound 4, half-maximal inhibitory concentration: > 10000 nM
Compound 4 gave a limit, no number (the forecaster's own chance of this, stated with the estimate: 80%); the middle value does not contradict the limit.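

Compound 4, like compound 1, compound 2 and compound 3, gives only a limit and not a number in this assay, so no step among these compounds can be read: the limit of > 10000 nM in this assay, at which 4 of the 4 values shown sit.

The compounds shown leave open how strongly each one inhibits, and whether changing the group on the amide-type nitrogen makes any difference.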